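The compounds below may be only part of what the source reports. "The series", "measured", "known", "first", "only" and "open" are said of these compounds alone.

Compound 1 `COc1ccc(-n2c(SCC(=O)c3ccc(OC)c(O)c3)nnc2-c2cc(OC)c(OC)c(OC)c2)cc1`, compound 2 `COc1ccc(-n2c(SCC(=O)c3ccc4ccccc4c3)nnc2-c2cc(OC)c(OC)c(OC)c2)cc1` and compound 3 `COc1ccc(C(=O)CSc2nnc(-c3cc(OC)c(OC)c(OC)c3)n2-c2ccc(N(C)C)cc2)cc1O` share one core and were all tested in a functional assay on HCT-116 cells (Homo sapiens) for inhibition, read by MTT assay, with a stated time of 48 h; a higher number here means a weaker inhibitor, a lower number a stronger inhibitor. In this assay compound 1 gives > 60000 nM, which is a limit of the assay and not a number. Compound 2 likewise gives only the limit > 60000 nM. Compound 3 gives > 100000 nM, again a limit rather than a number. The change from compound 1 to compound 2 is naphthalen-2-yl in place of 3-hydroxy-4-methoxyphenyl on a carbonyl carbon; its step that the two limits leave unreadable from compound 1 to compound 2 cannot be read because both values sit at the limit of > 60000 nM in this assay, at which 2 of the 3 values shown sit. The step that the two limits leave unreadable from compound 1 to compound 3 is equally unreadable, one value resting at the limit of > 60000 nM in this assay, at which 2 of the 3 values shown sit, and the other at the limit of > 100000 nM in this assay, at which 1 of the 3 values shown sits.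

Compound 4 `COc1cc(-c2nnc(SCC(=O)c3ccc4ccccc4c3)n2-c2ccc(N(C)C)cc2)cc(OC)c1OC` has not yet been measured. It differs from compound 3 by naphthalen-2-yl in place of 3-hydroxy-4-methoxyphenyl on a carbonyl carbon, the same kind of change as from compound 1 to compound 2; the surroundings of the place read the same, while the two cores differ by dimethylamino in place of methoxy on an aromatic carbon. The step from compound 3 to compound 4 is expected to be small, an at least 1.2-fold lower number from compound 3 to compound 4 (0.09 log units; that floor lies within the scatter), since compound 1 and compound 2 both sit at the limit of > 60000 nM in this assay, at which 2 of the 3 values shown sit. Compound 4 is therefore estimated at 80000 nM, likely between 30000 nM and 200000 nM.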

Compound 4, half-maximal inhibitory concentration: 54500 nM
Estimate against measurement, compound 4: 1.5-fold (0.17 log units) above; the measured number falls inside the stated range.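

In this assay, naphthalen-2-yl in place of 3-hydroxy-4-methoxyphenyl on a carbonyl carbon gives an at least 1.8-fold lower number from compound 3 to compound 4 (0.26 log units; that floor lies within the scatter), and dimethylamino in place of methoxy on an aromatic carbon gives an at least 1.1-fold lower number from compound 2 to compound 4 (0.04 log units; that floor lies within the scatter); both floors lie within the scatter, so neither step is shown to be real, though each could be larger. The same naphthalen-2-yl change on the other core, and the other steps among the first three compounds, cannot be read, because compound 1 and compound 2 both rest on a limit of the assay, not a number: the limit of > 60000 nM in this assay, at which 2 of the 4 values shown sit. Among these compounds, compound 4 therefore gives a measured number, but there is no step on a second core to set beside the new one, so nothing shows whether this change keeps its size from one core to another.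

The compounds shown leave open what other groups on the carbonyl carbon would do, such as an amine or a carboxylic acid in place of naphthalen-2-yl. They also leave open whether any such group would bring a number well clear of these limits.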